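Tetrazole acetamide series: aryl swap on the tetrazole

A few compounds are considered here, and "the series" means these few. Any claim that something is new, unique, unknown or untested is made for them only; others in the source may bear on it.

Measured so far:
compound 1, `Cc1cc(NC(=O)Cn2nnc(-c3ccccc3)n2)n(C2CCS(=O)(=O)C2)n1` — 1030 nM
compound 2, `Cc1cc(NC(=O)Cn2nnc(-c3cccc(Cl)c3)n2)n(C2CCCCC2)n1` — 300 nM

In an assay on HEK293 cells for activation of Kir3.1/Kir3.2 (Homo sapiens), read by thallium flux (on this read-out lower numbers stand for an effect already at smaller amounts and higher numbers for an effect only at larger amounts of compound), compound 2 gives 300 nM, the lower of the two numbers recorded; compound 1 sits higher, by more than the usual scatter, but it differs from compound 2 in two places at once, so its number serves only as a reference point and not as a single step.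

Compound 3, `COc1ccc(-c2nnn(CC(=O)Nc3cc(C)nn3C3CCCCC3)n2)cc1`, follows from compound 2 by one change: 4-methoxyphenyl in place of 3-chlorophenyl on an aromatic carbon. For the measured compounds named here, no measured pair shows this change in isolation, and nothing in the two recorded numbers speaks to it.

The step is expected to be modest, most likely toward a somewhat higher number but not clearly beyond the scatter: a 1.7-fold higher number from compound 2 to compound 3 (0.22 log units; within the scatter) is the expected size. Compound 3 is therefore expected to give about 500 nM in this assay, within a range of 150 nM to 1800 nM.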

Compound 3, half-maximal effective concentration: 175 nM
Compound 3: middle estimate off by 2.9-fold (0.46 log units), on the high side; measured number inside the range.
By their numbers in this assay, from the lowest: compounds 3 and 2 (each within the scatter of the next); then compound 1.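

In this assay, the exchange of 3-chlorophenyl for 4-methoxyphenyl on the aromatic carbon of the five-membered ring with 4 nitrogen gives a 1.7-fold lower number from compound 2 to compound 3 (0.23 log units; within the scatter), so compound 2 and compound 3 cannot be told apart on this read-out. This position therefore accepts a change of substituent, of where it sits on the phenyl ring and of hydrogen-bond acceptor count, with no step beyond the scatter. No measurement on hand accounts for the step.

The substituent and its place on the phenyl ring change together here, so their separate contributions cannot be read. Also open, as far as these compounds go, is how this assay would read with a carboxylic acid or a dimethylamino group on that phenyl ring, or with a longer chain such as butoxy in place of methoxy.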